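The source may hold more compounds than are shown below. What is called first, only, known or untested is meant among the compounds shown, and "the series" means these compounds.

Series of ureas linking a substituted phenyl ring to a pyridine. Compound 1 `Cc1cc(C)c(NC(=O)Nc2ccncc2)c(C)c1` gives 30 mg/kg in a functional assay on the whole organism with Mus musculus as the target, in the maximal electroshock model, with a stated time of 30 min; on this read-out higher numbers stand for an effect only at larger amounts of compound and lower numbers for an effect already at smaller amounts. Compound 2 `Cc1cc(C)c(NC(=O)Nc2ccncc2)c(Cl)c1` gives 100 mg/kg in this assay. The difference between them is chloro in place of methyl on an aromatic carbon and the step was a 3.3-fold higher number from compound 1 to compound 2 (0.52 log units; beyond the scatter). Compound 3 `Cc1cccc(C)c1NC(=O)Nc1ccccn1` gives 300 mg/kg in this assay; how its core differs from that of compound 1 is not broken down here. Compound 4 `Cc1cccc(Cl)c1NC(=O)Nc1ccccn1` is not yet measured; it differs from compound 3 by chloro in place of methyl on an aromatic carbon, the same kind of change as from compound 1 to compound 2, though there the place was meta to two methyl groups and here meta to a methyl group. Beside that earlier step, a step of a 2.0-fold higher number from compound 3 to compound 4 (0.30 log units; within the scatter) is expected for compound 4, resting on compound 3 and its value of 300 mg/kg. Compound 4 is estimated at 600 mg/kg in this assay, between 200 mg/kg and 1500 mg/kg.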

Compound 4, minimum effective dose: 100 mg/kg
Beside the measured number, compound 4's estimate is 6.0-fold (0.78 log units) above it; the whole stated range lies above it.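

Chloro in place of methyl gives a 3.0-fold lower number from compound 3 to compound 4 (0.48 log units; beyond the scatter) in this assay. Within the data shown here, on the core of compound 1 the same change ran the other way, so neither its size nor its direction can be carried from one core to the other: the same change on two cores in this assay, a 3.3-fold higher number (0.52 log units; beyond the scatter) from compound 1 to compound 2 and a 3.0-fold lower number (0.48 log units; beyond the scatter) from compound 3 to compound 4, 10-fold (1.00 log units) apart, beyond the scatter of two such steps With only one pair on each core, this does not show which feature of the two cores decides the direction, nor how the change would behave on a third core.

Open, from the compounds shown here alone, is how bromo, methoxy or trifluoromethyl in the same place would read on each core. Also open, going by these compounds, is whether either of them would follow chloro or methyl.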